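Nitro to methyl swap on the thioether arm

This account rests on a few compounds, and the source may have more. Where it says the series, first, only, none or still open, it means among the compounds named here.

Compound 1 `C=C1CC[C@@H]2[C@](C)(CO)[C@H](O)CC[C@@]2(C)[C@@H]1CC(Sc1ccc([N+](=O)[O-])cc1)C1=CCOC1=O` and compound 2 `C=C1CC[C@@H]2[C@](C)(CO)[C@H](O)CC[C@@]2(C)[C@@H]1C/C=C1/C(=O)OC[C@H]1OC(=O)CSc1ccc([N+](=O)[O-])cc1` share the same core. In a functional assay on PC-3 cells (Homo sapiens) for inhibition, read by MTT assay, with a stated time of 48 h (on this read-out higher numbers stand for weaker inhibition and lower numbers for stronger inhibition), compound 1 gives 17000 nM, and in this assay compound 2 gives 17000 nM, level with compound 1 within the scatter. Compound 3 `C=C1CC[C@@H]2[C@](C)(CO)[C@H](O)CC[C@@]2(C)[C@@H]1C/C=C1/C(=O)OC[C@H]1OC(=O)CSc1ccc(C)cc1` differs from compound 2 in one place: methyl in place of nitro on an aromatic carbon. Among the measured compounds shown here, no step between measured compounds covers this change. With compound 2 at 17000 nM sitting level with compound 1 at 17000 nM despite a large structural difference, the expected step is a 1.2-fold higher number from compound 2 to compound 3 (0.07 log units; within the scatter), none beyond the scatter. Compound 3 is therefore estimated at 20000 nM, between 7000 nM and 60000 nM.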

Compound 3, half-maximal inhibitory concentration: 27000 nM
Compound 3: the middle estimate sits 1.4-fold (0.13 log units) below what was measured; low and high end bracket the measured number.
By their numbers in this assay, from the lowest: compounds 1, 2 and 3 (each within the scatter of the next).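

In this assay, methyl in place of nitro on the aromatic carbon para to a large group gives a 1.6-fold higher number from compound 2 to compound 3 (0.20 log units; within the scatter). On these numbers, 4-nitrophenyl and 4-methylphenyl are not told apart at this position, so the nitro group is not required to keep the read-out at this level. Nothing available bears on why the number holds here. Going by these compounds, whether an amine or a carboxylic acid on the same aromatic carbon would move the number beyond the scatter remains open, as does whether the same swap would read alike on the thioether arm of compound 1.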